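Benzyl-substituted nucleosides tested for antiproliferative effect

A few compounds are considered here, and "the series" means these few. Any claim that something is new, unique, unknown or untested is made for them only; others in the source may bear on it.

Three compounds sharing a nucleoside core carrying a substituted benzylamine were examined in a functional assay on B16 cells (Mus musculus) for antiproliferative activity, with a stated time of 72 h; a lower number here means a stronger inhibitor, a higher number a weaker inhibitor. Compound 1 `Cc1cccc(CNc2ncnc3c2ncn3[C@@H]2O[C@H](CO)[C@@H](O)[C@H]2O)c1` carries a methylphenyl group. For compound 1 the result is a limit of the assay, > 166000 nM, and not a number. Compound 2 `COc1cccc(CNc2ncnc3c2ncn3[C@@H]2O[C@H](CO)[C@@H](O)[C@H]2O)c1OC` carries a dimethoxyphenyl group, and for compound 2 this assay reports "not determined" (no result reported). Compound 3 `COc1ccc(CNc2ncnc3c2ncn3C2OC(CO)[C@@H](O)[C@H]2O)c(O)c1` carries a methoxyphenyl bearing a hydroxy group, and for compound 3 this assay likewise reports "not determined" (no result reported). Compound 2 therefore stands without a number of its own; the only reading among these three is the limit for compound 1.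

Compound 4 `Cc1ccc(O)c(CNc2ncnc3c2ncn3[C@@H]2O[C@H](CO)[C@@H](O)[C@H]2O)c1` has not been measured. It differs from compound 2 by 2-hydroxy-5-methylphenyl in place of 2,3-dimethoxyphenyl on a saturated chain carbon bound to a nitrogen on an aromatic ring. Within the data shown here, no measured step between two compounds exists here, so the size and direction of the change from compound 2 to compound 4 in this assay cannot be read from these data. Among the measured compounds shown here, compound 4 is expected to be a weak inhibitor because the one reading available, for compound 1, sits at the limit of > 166000 nM in this assay, at which 1 of the 3 values shown sits. The estimate for compound 4 in this assay is 150000 nM, in the range 30000 nM to 600000 nM, with a fair chance that only a limit is reported.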

Compound 4, half-maximal inhibitory concentration: > 166000 nM
Compound 4: a limit, no number; the forecaster's own chance of this, stated with the estimate: 65%; middle value at least 1.1-fold (0.04 log units) from the limit.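

In this assay compound 4 gives > 166000 nM, a limit of the assay and not a number. Among these compounds, compound 1 also stands at a limit, so no step from compound 1 to compound 4 can be read. The compounds shown leave open what effect any of these phenyl groups has, for none of them carries a single number.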